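A few compounds are considered here, and "the series" means these few. Any claim that something is new, unique, unknown or untested is made for them only; others in the source may bear on it.

Compounds measured so far:
compound 1, `CN(Cc1cccc(F)c1)C(=O)c1cc2c(Cc3ccccc3)n[nH]c2cc1O`, in a functional assay on A2780 cells (Homo sapiens) for antiproliferative activity, read by resazurin assay, with a stated time of 72 h (on this read-out lower numbers stand for stronger inhibition and higher numbers for weaker inhibition), compound 1 gives 5000 nM;
compound 2, `CN(Cc1cccc(Cl)c1)C(=O)c1cc2c(Cc3ccccc3)n[nH]c2cc1O`, compound 2 gives 5300 nM;
compound 3, `Cc1cccc(CN(C)C(=O)c2cc3c(Cc4ccccc4)n[nH]c3cc2O)c1`, compound 3 gives "not determined" (no result reported), that is, no result was reported.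

Compound 1 holds the lowest of the two numbers, with compound 2 closest: a 1.1-fold higher number from compound 1 to compound 2 (0.03 log units; within the scatter), which tells nothing of order. Compound 4, `COc1cc(CN(C)C(=O)c2cc3c(Cc4ccccc4)n[nH]c3cc2O)ccc1Cl`, differs from compound 1 by 4-chloro-3-methoxyphenyl in place of 3-fluorophenyl on a saturated chain carbon bound to an amide-type nitrogen. For the measured compounds named here, no measured step covers a methoxy addition; the only step available, the halogen swap from compound 1 to compound 2, stayed within the scatter, and compound 3 gives no number. The step is therefore expected to be small, with no clear direction. Compound 4 is estimated at 5000 nM, between 2000 nM and 15000 nM, a step of no change at the digits printed from compound 1 to compound 4 (within the scatter).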

Compound 4, half-maximal inhibitory concentration: 4100 nM
The estimate for compound 4 lay 1.2-fold (0.09 log units) above the measured number; measured number inside the range.
By their numbers in this assay, from the lowest: compounds 4, 1 and 2 (each within the scatter of the next).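

In this assay the entry of 4-chloro-3-methoxyphenyl gives a 1.2-fold lower number from compound 1 to compound 4 (0.09 log units; within the scatter) and a 1.3-fold lower number from compound 2 to compound 4 (0.11 log units; within the scatter) at this place, on a saturated chain carbon bound to an amide-type nitrogen. The earlier compounds shown here showed only a halogen swap here; compound 4 shows that a ring carrying both chloro and methoxy also stays within the scatter of them. No measurement available explains this result.

Steps to compound 3 cannot be read. Going by these compounds, whether an amine, a carboxylic acid or a longer chain at this place would shift the number beyond the scatter remains open.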